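The source may report more compounds than this note shows. Statements on the series, on what has been measured and on what is new or still open speak of the compounds shown alone.

Of the compounds shown here, two have numbers so far in a functional assay on MCF7 cells (Homo sapiens) for antiproliferative activity, read by CCK-8 assay, with a stated time of 48 h; a lower number here means a stronger inhibitor, a higher number a weaker inhibitor. Compound 1 `O=C(/C=C/CNCCOc1ccc(Oc2c(-c3ccc(F)cc3)sc3cc(O)ccc23)cc1)N1CCCC1` gives 7610 nM, and compound 2 `C/C=C/C(=O)NCCOc1ccc(Oc2c(-c3ccc(F)cc3)sc3cc(O)ccc23)cc1` gives 21700 nM, the higher of the two and so the weaker result. Compound 3 `O=C(/C=C/CNCCOc1ccc(Oc2c(-c3ccc(F)cc3)sc3cc(O)ccc23)cc1)N1CCCCC1` differs from compound 2 in one place: 3-((piperidin-1-yl)carbonyl)prop-2-en-1-yl in place of (prop-1-en-1-yl)carbonyl on an amine nitrogen. In words, 3-((piperidin-1-yl)carbonyl)prop-2-en-1-yl stands in place of (prop-1-en-1-yl)carbonyl on an amine nitrogen. For the measured compounds named here, only one measured step bears on this change: a 2.9-fold higher number from compound 1 to compound 2 (0.46 log units; beyond the scatter), which is modest but beyond the scatter. That step swaps 3-((pyrrolidin-1-yl)carbonyl)prop-2-en-1-yl for the same (prop-1-en-1-yl)carbonyl, so going the opposite way should lower the number by a similar amount. One pair is thin evidence, so the range stays wide. The expected change is a 2.9-fold lower number from compound 2 to compound 3 (0.46 log units; beyond the scatter). For compound 3 the estimated value is 7500 nM, with an expected range from 3500 nM to 16000 nM.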

Compound 3, half-maximal inhibitory concentration: 16400 nM
For compound 3 the middle estimate is 2.2-fold (0.34 log units) below the measured one, and the stated range ends below it.
By their numbers in this assay, from the lowest: compound 1; then compounds 3 and 2 (each within the scatter of the next).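

In this assay the longer side chain ending in a piperidine amide does not reproduce the gain seen with the pyrrolidine amide: this change on the amine nitrogen gives a 1.3-fold lower number from compound 2 to compound 3 (0.12 log units; within the scatter) and so leaves the two compounds indistinguishable. The ring on the terminal carbonyl therefore matters here, as piperidin-1-yl in place of pyrrolidin-1-yl gives a 2.2-fold higher number from compound 1 to compound 3 (0.33 log units; beyond the scatter) and this modest step removes most of that gain. Nothing measured here explains the difference between these two rings.

Going by these compounds, whether ring size alone governs this result remains open, and an azetidine or a morpholine on the same carbonyl carbon would test that. An open-chain dimethylamine there would also show whether any ring is needed at all.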